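The compounds below may be only part of what the source reports. "The series", "measured", "known", "first", "only" and "open" are said of these compounds alone.

Two compounds share one core. Compound 2 `CCN(CC)CCNC(=O)c1cc(C(CC)(CC)c2ccc(C#CC(O)(CC)CC)c(C)c2)cn1CC` carries a (2-(diethylamino)ethyl)carbamoyl group; in an assay on cells for agonist activity at vitamin D3 receptor (Homo sapiens), read by microscopy (on this read-out lower numbers stand for an effect already at smaller amounts and higher numbers for an effect only at larger amounts of compound), compound 2 gives 6.98 nM, the lowest of the two numbers. Compound 1 `CCn1c(C(=O)NCCC(=O)O)ccc1C(CC)(CC)c1ccc(C#CC(O)(CC)CC)c(C)c1` gives 293 nM in this assay, which lies beyond the scatter of compound 2. Compound 3 `CCn1cc(C(CC)(CC)c2ccc(C#CC(O)(CC)CC)c(C)c2)cc1C(=O)NCC(=O)O` has not been measured. It differs from compound 2 by carboxy in place of (diethylamino)methyl on a saturated chain carbon bound to an amide-type nitrogen. With compound 1 showing 293 nM, a weaker effect is expected after this change, so the step from compound 2 to compound 3 is estimated as a 10-fold higher number from compound 2 to compound 3 (1.00 log units; beyond the scatter). Compound 3 is expected to give about 70 nM, likely between 15 nM and 400 nM.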

Compound 3, half-maximal effective concentration: 54.3 nM
Compound 3: the middle estimate sits 1.3-fold (0.11 log units) above what was measured; the range from low to high includes it.
By their numbers in this assay, from the lowest: compound 2; then compound 3; then compound 1.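

In this assay, putting carboxy in place of (diethylamino)methyl on a saturated chain carbon bound to an amide-type nitrogen gives a 7.8-fold higher number from compound 2 to compound 3 (0.89 log units; beyond the scatter) and so shows that this position responds to the change. Even so, compound 3 still gives 54.3 nM with the carboxy group in place, so the effect needs more compound but is not lost. Nothing measured here explains this step. Still open, from the compounds shown here alone, is whether the step follows from gaining carboxy or from losing the diethylamino part. A hydroxymethyl group or a plain aminomethyl group at this place could help separate the two.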